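This account rests on a few compounds, and the source may have more. Where it says the series, first, only, none or still open, it means among the compounds named here.

In an ADME assay on a cell-free system (plasma, Rattus norvegicus) for protein binding, compound 2 `Cc1ccc(-c2cc(C(=O)N[C@H](C)c3ccc(F)cn3)cc(C(C)(C)O)c2)nc1` gives 82%. Compound 1 `Cc1ccc(-c2cc(C(=O)N[C@H](C)c3ccc(C(F)(F)F)nc3)cc(C(C)(C)O)c2)nc1` gives 95.2%, so compound 2 has the larger unbound fraction of the two measured compounds. Compound 3 `Cc1ccc(-c2cc(C(=O)N[C@H](C)c3ccc(F)cn3)cc(-n3nccn3)c2)nc1` keeps the 5-fluoropyridin-2-yl group of compound 2 and differs at another site, with 2H-1,2,3-triazol-2-yl in place of 1-hydroxy-1-methylethyl on an aromatic carbon.

Among the measured compounds shown here, only one measured step is available, a 3.8-fold higher unbound fraction from compound 1 to compound 2 (0.57 log units; beyond the scatter). It involves a different place in the molecule, so it says nothing direct about this exchange and only shows how far one group exchange can move this assay. For the measured compounds named here, no measured compound carries the 2H-1,2,3-triazol-2-yl group, so the direction remains a judgement. A step of similar or smaller size toward a lower unbound fraction seems the likelier outcome, although little change is also possible. The expected step is a 1.8-fold lower unbound fraction from compound 2 to compound 3 (0.26 log units; within the scatter), and this estimate is uncertain. For compound 3 the estimated value is 90%, with a range from 80% to 96%.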

Compound 3, plasma protein binding: 97.4%
The estimate for compound 3 lay 3.8-fold (0.59 log units) (unbound fraction) above the measured number; the whole stated range lies below it.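

Among the compounds shown here, the earlier pair showed only that the group on the saturated chain carbon can shift the reading in this assay and left the other side of the molecule untested. This result shows that the aromatic carbon meta to a 5-methylpyridin-2-yl group matters as well: putting 2H-1,2,3-triazol-2-yl in place of 1-hydroxy-1-methylethyl there gives a 6.9-fold lower unbound fraction from compound 2 to compound 3 (0.84 log units; beyond the scatter) and lies beyond the usual scatter. The exchange removes the hydrogen-bond donor, adds hydrogen-bond acceptors and brings in a five-membered aromatic ring all at once, and no available measurement explains the shift or separates these differences.

Going by these compounds, it remains open whether a small group such as a primary amine or a carboxylic acid on this aromatic carbon would give a reading closer to that of compound 2 or compound 3, and whether a simple hydroxymethyl group would behave like 1-hydroxy-1-methylethyl. On these data alone, it is also open whether the same exchange would move the reading as far in a compound carrying the 6-(trifluoromethyl)pyridin-3-yl group of compound 1.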